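Adding a bromo group to the anilide ring of compound 1

A few compounds are considered here, and "the series" means these few. Any claim that something is new, unique, unknown or untested is made for them only; others in the source may bear on it.

Compound 1, with the structure `O=C(CSc1nncnc1-c1ccccc1Cl)Nc1ccccc1`, was tested in an ADME assay on MT4 cells (Homo sapiens) for cytotoxicity, read by MTT assay (a higher number here means that more compound is tolerated, a lower number that less compound is tolerated), where compound 1 gives 127000 nM. That is the lower of the two numbers gathered so far, but its companion compound 2, `Cc1ccc(NC(=O)CSc2nncnc2-c2ccccc2Cl)c([N+](=O)[O-])c1`, which in this assay gives 158000 nM, sits within the scatter of repeated measurements, so the two cannot be told apart. Compound 3, `O=C(CSc1nncnc1-c1ccccc1Cl)Nc1ccccc1Br`, has not yet been measured. It differs from compound 1 by bromo in place of hydrogen on an aromatic carbon. Among the measured compounds shown here, with only two compounds measured and both equally tolerated, there is no step to lean on. The expectation is that compound 3 stays close to compound 1, and the estimated step of a 1.2-fold lower number from compound 1 to compound 3 (0.06 log units; within the scatter) lies within the usual scatter. Compound 3 is therefore expected to give about 110000 nM in this assay, with a likely range from 50000 nM to 250000 nM.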

Compound 3, half-maximal cytotoxic concentration: 73000 nM
Beside the measured number, compound 3's estimate is 1.5-fold (0.18 log units) above it, and the stated range covers the measured number.
By their numbers in this assay, from the lowest: compounds 3, 1 and 2 (each within the scatter of the next, the first and the last beyond it).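

In this assay the step is a 1.7-fold lower number from compound 1 to compound 3 (0.24 log units; within the scatter) for bromo in place of hydrogen on an aromatic carbon, ortho to a large group. Among the compounds shown here, this is the first direct look at a single change on this six-membered aromatic ring, and it shows that one added bromine atom at this position leaves compound 3 indistinguishable from compound 1 in how much is tolerated. Nothing available bears on what lies behind this result. As far as these compounds go, whether an amine, a carboxylic acid or a methoxy group on the same carbon would shift the number beyond the scatter remains open. From the compounds shown here alone, it is also open whether bromo on another carbon of this ring would behave as it does here.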